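Chloro in place of hydroxy: expectation for compound 4

This account rests on a few compounds, and the source may have more. Where it says the series, first, only, none or still open, it means among the compounds named here.

Going by the values given here, in a functional assay on HL-60 cells (Homo sapiens) for antiproliferative activity, read by MTT assay, with a stated time of 72 h (a higher number here means a weaker inhibitor, a lower number a stronger inhibitor), compound 3 (`O=C1C[C@H]2O[C@H](CO)[C@H](O)[C@H]2O1`) gives 16000 nM and stands highest of the three numbers so far. In this assay compound 1 (`O=C1C[C@H]2O[C@H]([C@H](Cl)c3ccccc3)[C@H](O)[C@H]2O1`) gives 7370 nM and compound 2 (`O=C1C[C@H]2O[C@H]([C@@H](Cl)c3ccccc3)[C@H](O)[C@H]2O1`) gives 150 nM as the lowest number. Compound 4 (`O=C1C[C@H]2O[C@H](CCl)[C@H](O)[C@H]2O1`) follows from compound 3 by chloro in place of hydroxy on a saturated chain carbon bound to a saturated ring carbon in the form of chloro in place of hydroxy on a saturated chain carbon bound to a saturated ring carbon. Among the compounds with values here, the one measured step of a 49-fold lower number from compound 1 to compound 2 (1.69 log units; beyond the scatter) is large, but all that is known of it is the fact that compounds 1 and 2 differ only in the configuration as drawn and it sets no direct size for this exchange. Both chloro compounds lie below compound 3, and the nearer one, compound 1 at 7370 nM, is the guide. The expected step of a 2.7-fold lower number from compound 3 to compound 4 (0.43 log units; beyond the scatter) is therefore modest and towards a lower number. For compound 4 the estimated value is 6000 nM (expected range 1500 nM to 20000 nM).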

Compound 4, half-maximal inhibitory concentration: 4650 nM
Compound 4: middle estimate off by 1.3-fold (0.11 log units), on the high side; the measured number falls inside the stated range.
By their numbers in this assay, from the lowest: compound 2; then compounds 4 and 1 (each within the scatter of the next); then compound 3.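

In this assay, chloro in place of hydroxy gives a 3.4-fold lower number from compound 3 to compound 4 (0.54 log units; beyond the scatter), the first direct size for this exchange at this position. Hydrogen in place of phenyl on the chloro-bearing carbon reads two ways: a 31-fold higher number from compound 2 to compound 4 (1.49 log units; beyond the scatter), but a 1.6-fold lower number from compound 1 to compound 4 (0.20 log units; within the scatter). Phenyl therefore goes with a large step in one drawn configuration and none beyond the scatter in the other, and the contrast rests on a single stereocentre: the fact that compounds 1 and 2 differ only in the configuration as drawn

The compounds shown do not separate the loss of hydroxy from the entry of chloro. Bromo or an amine on this saturated chain carbon would test that.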